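Allenic benzylamine series: the amine nitrogen methyl

The compounds below may be only part of what the source reports. "The series", "measured", "known", "first", "only" and "open" are said of these compounds alone.

The pair measured so far covers two allenic amines. Compound 1 `C=C=CCN(C)Cc1ccccc1` gives 170 nM in an assay on isolated protein for inhibition of Monoamine oxidase (Rattus norvegicus) (a lower number here means a stronger inhibitor, a higher number a weaker inhibitor), and compound 2 `C=C=C(CN)Cc1ccc(C)cc1` gives 360 nM in the same assay. Compound 1 holds the lowest of the two numbers, and the gap to compound 2 lies beyond the usual scatter; the two differ in more than one place, so the numbers alone carry the comparison.

The next compound, compound 3 `C=C=CCNCc1ccccc1`, keeps the core of compound 1 and differs only by hydrogen in place of methyl on an amine nitrogen. For the measured compounds named here, no measured pair isolates this change, so nothing in the numbers fixes its size. The expectation for compound 3 is a moderate step to a weaker inhibitor, a 2.4-fold higher number from compound 1 to compound 3 (0.37 log units; beyond the scatter), with the possibility of no change beyond the scatter kept open. Compound 3 is expected to give about 400 nM in this assay, between 120 nM and 1500 nM.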

Compound 3, half-maximal inhibitory concentration: 150 nM
Estimate against measurement, compound 3: 2.7-fold (0.43 log units) above, and the stated range covers the measured number.
By their numbers in this assay, from the lowest: compounds 3 and 1 (each within the scatter of the next); then compound 2.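

For the compounds shown here, this is the first pair that isolates the amine nitrogen. In this assay the change to hydrogen in place of methyl gives a 1.1-fold lower number from compound 1 to compound 3 (0.05 log units; within the scatter) and so leaves the number without a change that can be read. On the core of compound 1, the methyl on this nitrogen can therefore be removed without a readable loss or gain in this measure, although one pair on one core supports no wider rule. Going by these compounds alone, nothing measured so far bears on why the step is this small.

Still open, from the compounds shown here alone, is how this assay responds to something larger than methyl on this nitrogen, such as an ethyl group, a longer chain or an acetyl group. Also open, going by these compounds, is whether hydrogen and methyl stay equivalent on a core carrying a methyl on the benzene ring.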